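Swapping the Prenyl Ether for a Bromobenzyl Ether

The source may hold more compounds than are shown below. What is called first, only, known or untested is meant among the compounds shown, and "the series" means these compounds.

Of the compounds shown here, three sharing one core have been measured in a functional assay on HepG2 cells (Homo sapiens) for antiproliferative activity, read by MTT assay, with a stated time of 24 h; a lower number here means a stronger inhibitor, a higher number a weaker inhibitor. Compound 1 `COc1cc(OC)c(-c2coc3cc(OCC=C(C)C)ccc3c2=O)cc1OC` carries a (3-methylbut-2-en-1-yl)oxy group and gives 280 nM, the lowest number of the three. Compound 2 `COc1cc(OC)c(-c2coc3cc(OCc4ccccc4)ccc3c2=O)cc1OC` gives 1320 nM, and compound 3 `COc1cc(OC)c(-c2coc3cc(OCc4ccccc4F)ccc3c2=O)cc1OC` gives 1280 nM.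

Two steps describe what happens when the open chain is replaced by an aromatic ring at the same position: a 4.7-fold higher number from compound 1 to compound 2 (0.67 log units; beyond the scatter), and a 4.6-fold higher number from compound 1 to compound 3 (0.66 log units; beyond the scatter). Adding fluorine to the ring changed little: a 1.0-fold lower number from compound 2 to compound 3 (0.01 log units; within the scatter).

Compound 4 `COc1cc(OC)c(-c2coc3cc(OCc4ccc(Br)cc4)ccc3c2=O)cc1OC` is not yet measured. Compared with compound 1, the change is 4-bromophenyl in place of 2-methylprop-1-en-1-yl on a saturated chain carbon bound to an oxygen on an aromatic ring. This mirrors the two measured steps from compound 1, each a modest rise of similar size, so a rise of about the same size is expected in this assay, as a 4-bromophenyl is another aromatic ring in the same place. Compound 4 is therefore expected to give 1300 nM, within the range 600 nM to 2800 nM, which means an expected step of a 4.6-fold higher number from compound 1 to compound 4 (0.67 log units; beyond the scatter).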

Compound 4, half-maximal inhibitory concentration: 1050 nM
For compound 4 the middle estimate is 1.2-fold (0.09 log units) above the measured one; the range from low to high includes it.
By their numbers in this assay, from the lowest: compound 1; then compounds 4, 3 and 2 (each within the scatter of the next).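

In this assay, the rise seen on leaving the 3-methylbut-2-en-1-yl chain appears for a third aromatic ring, with a 3.8-fold higher number from compound 1 to compound 4 (0.57 log units; beyond the scatter), so it also holds with bromine on that ring. Bromine hardly matters among the benzyl ethers: a 1.3-fold lower number from compound 2 to compound 4 (0.10 log units; within the scatter) and a 1.2-fold lower number from compound 3 to compound 4 (0.09 log units; within the scatter), so the 4-bromobenzyl, 2-fluorobenzyl and plain benzyl groups cannot be told apart, and neither halogen brings the number back towards that of compound 1. Nothing available here explains why the open chain gives the lower number.

Still open, from the compounds shown here alone, is whether a saturated 3-methylbutyl chain would give a number like that of compound 1 or like those of the benzyl ethers. Also open, going by these compounds, is how a longer chain such as geranyl, or a benzyl ring bearing an amine, would behave.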